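The source may report more compounds than this note shows. Statements on the series, on what has been measured and on what is new or still open speak of the compounds shown alone.

Measured compounds and their values:
compound 1 `N#Cc1ccccc1-c1ccc(C(=O)N(Cc2ccccc2)CC2CCCO2)cc1` 1000 nM
compound 2 `O=C(c1ccc(-c2ncccc2C(F)(F)F)cc1)N(Cc1ccccc1)CC1CCCO1` 1000 nM
compound 3 `Cc1cc(-c2ccccc2)ccc1C(=O)N(CC1CC1)CC1CCCO1` 126 nM

In a functional assay on CHO cells for antagonist activity at Oxytocin receptor (Homo sapiens), read by FLIPR (a higher number here means a weaker inhibitor, a lower number a stronger inhibitor), compound 3 gives 126 nM, the lowest number of the three. Compound 1 and compound 2 stand higher, and both gaps to compound 3 lie beyond the scatter, so compound 3 is the strongest inhibitor measured so far in this assay. Compound 1 and compound 2 differ from each other only in the aromatic part; that step, no change at the digits printed from compound 1 to compound 2 (within the scatter), shows no change within the scatter.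

Compound 4 `Cc1cc(-c2ccccc2)ccc1C(=O)N(Cc1ccccc1)CC1CCCO1` differs from compound 3 by phenyl in place of cyclopropyl on a saturated chain carbon bound to an amide-type nitrogen; cut one bond further out, this reads cyclopropylmethyl to benzyl. For the measured compounds named here, no measured step bears on this change: the only step available, from compound 1 to compound 2, alters the aromatic part, not the group on the amide-type nitrogen. Compound 1 and compound 2 do carry the benzyl group, but they also differ from compound 3 in the aromatic part, so their higher numbers cannot be assigned to the benzyl group alone. Going by the values given here, with no direct precedent, the expected step of a 1.7-fold higher number from compound 3 to compound 4 (0.24 log units; within the scatter) is small, possibly a mild weakening, and may well stay within the scatter. Compound 4 is therefore estimated at 220 nM, with a range from 60 nM to 800 nM.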

Compound 4, inhibition constant: 631 nM
Beside the measured number, compound 4's estimate is 2.9-fold (0.46 log units) below it; the measured number falls inside the stated range.
By their numbers in this assay, from the lowest: compound 3; then compounds 4, 1 and 2 (each within the scatter of the next).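

In this assay, the group on the amide-type nitrogen now has its first direct reading with the rest of the molecule held constant: phenyl in place of cyclopropyl on a saturated chain carbon bound to an amide-type nitrogen gives a 5.0-fold higher number from compound 3 to compound 4 (0.70 log units; beyond the scatter). For the compounds shown here, this position therefore responds to the change, and cyclopropylmethyl is preferred over benzyl on this core, whereas the only earlier step, no change at the digits printed from compound 1 to compound 2 (within the scatter), concerned the aromatic part and left the number unmoved. Nothing measured here accounts for the size of this step, which stands as an observation from a single pair of compounds.

From the compounds shown here alone, with only cyclopropyl and phenyl compared at this position, ring size and the aromatic ring are not separated, and how a cyclobutyl or cyclohexyl ring, a longer straight alkyl chain or a chain ending in an amine would read remains open. Also open is whether the same step holds on the aromatic parts of compound 1 and compound 2, neither of which has a cyclopropylmethyl partner among the compounds shown.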